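This account rests on a few compounds, and the source may have more. Where it says the series, first, only, none or still open, it means among the compounds named here.

Compound 2 `COc1ccccc1-c1csc(N/N=C/c2cc(OC)c(OC)c(Br)c2Br)n1` stands at a limit: in a functional assay on U-87MG ATCC cells for inhibition, with U-87 MG (Homo sapiens) as the target, read by MTT assay, with a stated time of 48 h (a lower number here means a stronger inhibitor, a higher number a weaker inhibitor), compound 2 gives > 100000 nM, which is a limit of the assay and not a number. Compound 1 `COc1cc(/C=N/Nc2nc(-c3ccc(C(F)(F)F)cc3)cs2)c(Br)c(Br)c1OC` also reaches only a limit, giving > 100000 nM in this assay. The step that the two limits leave unreadable from compound 1 to compound 2 is accordingly unreadable, as the limit of > 100000 nM in this assay, at which 2 of the 2 values shown sit, shows. Compound 3 `COc1cc(/C=N/Nc2nc(-c3cccc(Br)c3)cs2)c(Br)c(Br)c1OC` differs from compound 2 by 3-bromophenyl in place of 2-methoxyphenyl on an aromatic carbon. Among the measured compounds shown here, no measured step offers a readable size, so no direction can be drawn from the data. Compound 3 is expected to stay near the limit, with an estimated step that the limit leaves unreadable from compound 2 to compound 3. Compound 3 is estimated at 150000 nM, between 30000 nM and 1000000 nM.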

Compound 3, half-maximal inhibitory concentration: 27600 nM
Compound 3: middle estimate off by 5.4-fold (0.74 log units), on the high side; the whole stated range lies above it.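

The aryl group on the aromatic carbon next to the ring nitrogen can move the result in this assay, which the two earlier compounds could not show: 3-bromophenyl in place of 2-methoxyphenyl gives an at least 3.6-fold lower number from compound 2 to compound 3 (0.55 log units; beyond the scatter). 3-Bromophenyl in place of 4-(trifluoromethyl)phenyl gives an at least 3.6-fold lower number from compound 1 to compound 3 (0.55 log units; beyond the scatter). One end of each step is a limit of the assay, so each size is only a bound.

Which feature of 3-bromophenyl carries this change stays open. So does how a phenyl bearing an amine or a carboxylic acid would read at this position.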